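The compounds below may be only part of what the source reports. "The series", "measured", "known", "first", "only" and "open" are said of these compounds alone.

Measured so far in a functional assay on HL-60 cells (Homo sapiens) for inhibition, read by sulforhodamine B assay, with a stated time of 48 h, tested at 10 uM; on this read-out lower numbers stand for less inhibition and higher numbers for more inhibition at the one concentration tested (going by the name of the read-out):
compound 1 `O=Cc1ccc(-c2cn3ccnc3c(-c3ccc4ncn(C5CCCCC5)c4c3)n2)cc1`, 16.5%
compound 2 `Fc1ccc(-c2cn3ccnc3c(-c3ccc4ncn(C5CCCCC5)c4c3)n2)cc1`, 2.03%
compound 3 `Brc1ccc(-c2cn3ccnc3c(-c3ccc4ncn(C5CCCCC5)c4c3)n2)cc1`, 23.2%

Compound 3 stands highest of the three numbers; its gap to compound 1 is within the scatter, a number 6.7 percentage points higher from compound 1 to compound 3 (within the scatter), whereas its gap to compound 2 is beyond it, a number 21.2 percentage points higher from compound 2 to compound 3 (beyond the scatter). Compound 4 `Fc1ccccc1-c1cn2ccnc2c(-c2ccc3ncn(C4CCCCC4)c3c2)n1` is not yet measured. (2-fluorophenyl in place of 4-bromophenyl on an aromatic carbon). Among the compounds with values here, the one measured step that bears on this change is a number 21.2 percentage points higher from compound 2 to compound 3 (beyond the scatter), which exchanged the same two halogens on the phenyl group; here the entering group is 2-fluorophenyl, and no measured pair speaks to that group. A drop of similar order is therefore expected, a number 15.2 percentage points lower from compound 3 to compound 4 (beyond the scatter). For compound 4 the estimate is 8%, range 0% to 25%.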

Compound 4, a percentage reported as inhibition, at one concentration (the size of the read-out at that concentration, not a potency): 9.3%
Compound 4: the middle estimate sits 1.3 percentage points below what was measured, and the stated range covers the measured number.
By their numbers in this assay, from the lowest: compounds 2, 4, 1 and 3 (each within the scatter of the next, the first and the last beyond it).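

In this assay, moving the fluorine around the phenyl group does not separate the 2-fluorophenyl group from the 4-fluorophenyl group (a number 7.3 percentage points higher from compound 2 to compound 4 (within the scatter)). The 2-fluorophenyl group is also not told apart from 4-formylphenyl (a number 7.2 percentage points lower from compound 1 to compound 4 (within the scatter)), but it does stand apart from 4-bromophenyl (a number 13.9 percentage points lower from compound 3 to compound 4 (beyond the scatter)). No data on hand explain these steps.

Still open, on these data alone, is whether 2-bromophenyl would match 4-bromophenyl, and whether an amine or a carboxylic acid on the phenyl group would give a number beyond that of compound 3 23.2%.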